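The source may hold more compounds than are shown below. What is called first, only, known or untested is meant among the compounds shown, and "the series" means these compounds.

Compound 1 has the structure `C/C(=C\CC/C(C)=C/CC[C@@H]1[C@@]2(C)CCC(=O)C(C)(C)[C@H]2CC[C@@]1(C)O)CC/C=C(\C)C(=O)OCc1cn(-c2ccccc2[N+](=O)[O-])nn1`. In a functional assay on A549 cells (Homo sapiens) for antiproliferative activity, read by MTT assay, with a stated time of 48 h (a higher number here means a weaker inhibitor, a lower number a stronger inhibitor), compound 1 reaches only the limit of the measurement, > 150000 nM. Two neighbours share its core and differ from it in the group on the aromatic nitrogen. Compound 2, `C/C(=C\CC/C(C)=C/CC[C@@H]1[C@@]2(C)CCC(=O)C(C)(C)[C@H]2CC[C@@]1(C)O)CC/C=C(\C)C(=O)OCc1cn(-c2ccc(F)c(Cl)c2)nn1`, carries 3-chloro-4-fluorophenyl in place of 2-nitrophenyl. In this assay compound 2 likewise ends at a limit, > 150000 nM. Compound 3, `C/C(=C\CC/C(C)=C/CC[C@@H]1[C@@]2(C)CCC(=O)C(C)(C)[C@H]2CC[C@@]1(C)O)CC/C=C(\C)C(=O)OCc1cn(-c2ccccc2)nn1`, has hydrogen in place of nitro on an aromatic carbon. In this assay compound 3 also gives a limit, > 150000 nM. The steps among these three cannot be sized: a step that the two limits leave unreadable from compound 1 to compound 2, a step that the two limits leave unreadable from compound 1 to compound 3 and a step that the two limits leave unreadable from compound 2 to compound 3 all stay hidden since (the limit of > 150000 nM in this assay, at which 3 of the 3 values shown sit). Compound 4, `C/C(=C\CC/C(C)=C/CC[C@@H]1[C@@]2(C)CCC(=O)C(C)(C)[C@H]2CC[C@@]1(C)O)CC/C=C(\C)C(=O)OCc1cn(-c2ccccc2Cl)nn1`, is the next member of the set: chloro in place of nitro on an aromatic carbon. The measured steps bear on it only in that none of the three variations at this position moved a value off the limit, so no step beyond the scatter can be read in either direction. Compound 1 itself sits at a limit, and compound 4 is expected to do the same, with a step that the limit leaves unreadable from compound 1 to compound 4 expected to remain unreadable. The estimate for compound 4 is 200000 nM, within a range from 80000 nM to 1000000 nM.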

Compound 4, half-maximal inhibitory concentration: > 150000 nM
Compound 4 was reported as a limit; the forecaster's own chance of this, stated with the estimate: 85%; the middle value does not contradict the limit.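

In this assay compound 4 also gives only a limit, so its steps from compound 1, compound 2 and compound 3 cannot be read: the limit of > 150000 nM in this assay, at which 4 of the 4 values shown sit.

The compounds shown leave open how far compound 1, compound 2, compound 3 and compound 4 lie from one another, and whether any other group on the aromatic nitrogen would give a measurable value.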